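A few compounds are considered here, and "the series" means these few. Any claim that something is new, unique, unknown or untested is made for them only; others in the source may bear on it.

Measured in an ADME assay on Vero cells (Chlorocebus sabaeus) for cytotoxicity; a higher number here means that more compound is tolerated, a lower number that less compound is tolerated:
- compound 1, `O=C(NCCO)c1cccc2[nH]c(-c3ccccn3)nc12`, gives 568 uM
- compound 2, `O=C(Nc1ccccc1)c1cccc2[nH]c(-c3ccccn3)nc12`, gives 17.9 uM
- compound 3, `O=C(Nc1ccccc1F)c1cccc2[nH]c(-c3ccccn3)nc12`, gives 54.7 uM

Compound 2 has the lowest number of the three in this assay, meaning it is the least tolerated. Its nearest neighbour is compound 3, as the step of a 3.1-fold higher number from compound 2 to compound 3 (0.49 log units; beyond the scatter) shows, and the furthest is compound 1, which lies a 32-fold lower number from compound 1 to compound 2 (1.50 log units; beyond the scatter).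

Compound 4, `O=C(Nc1ccccc1)c1cccc2[nH]c(-c3cccnc3)nc12`, is compound 2 with one change: pyridin-3-yl in place of pyridin-2-yl on an aromatic carbon. The three measured steps all concern the group on the amide-type nitrogen: a 32-fold lower number from compound 1 to compound 2 (1.50 log units; beyond the scatter) and a 10-fold lower number from compound 1 to compound 3 (1.02 log units; beyond the scatter) were large, and a 3.1-fold higher number from compound 2 to compound 3 (0.49 log units; beyond the scatter) was modest. For the measured compounds named here, none of them touches the ring attached to the shared core, so no measured step bears directly on this change. With nothing pointing either way, a step of no size beyond the scatter is expected in this assay, that is, a 1.0-fold higher number from compound 2 to compound 4 (0.00 log units; within the scatter). Compound 4 is therefore estimated at 18 uM, within a range from 6 uM to 55 uM.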

Compound 4, half-maximal toxic concentration: 34.2 uM
Beside the measured number, compound 4's estimate is 1.9-fold (0.28 log units) below it, and the stated range covers the measured number.
By their numbers in this assay, from the lowest: compounds 2, 4 and 3 (each within the scatter of the next, the first and the last beyond it); then compound 1.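

For the compounds shown here, this is the first step that changes the ring on the aromatic carbon between the two ring nitrogen atoms, rather than the group on the amide-type nitrogen. In this assay, exchanging pyridin-2-yl for pyridin-3-yl gives a 1.9-fold higher number from compound 2 to compound 4 (0.28 log units; within the scatter), so in this pair, with the phenyl amide held constant, the two pyridine attachments cannot be told apart. By contrast, the change on the amide-type nitrogen in a 32-fold lower number from compound 1 to compound 2 (1.50 log units; beyond the scatter) is beyond the scatter, and no supporting evidence is available to explain either result.

As far as these compounds go, whether a pyridin-4-yl group or a saturated ring such as piperidine at this place would also stay within the scatter remains open. From the compounds shown here alone, it is also open whether pyridin-3-yl would behave the same way with the 2-hydroxyethyl amide of compound 1 or the 2-fluorophenyl amide of compound 3.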